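Thiazole Swapped for Dichlorophenyl on the Sulfonyl Sulfur

The source may report more compounds than this note shows. Statements on the series, on what has been measured and on what is new or still open speak of the compounds shown alone.

Going by the values given here, compound 3 `Cc1nc(Cl)sc1S(=O)(=O)N1CCC(N2CCC(C)CC2)CC1` is the only member of this set with a numbered result: in a functional assay on DLD-1 cells (Homo sapiens) for antiproliferative activity, read by CellTiter-Glo, with a stated time of 72 h (a higher number here means a weaker inhibitor, a lower number a stronger inhibitor), compound 3 gives 1.6 nM. Compound 1 `CCc1ccc(S(=O)(=O)N2CCC(N3CCC(C)CC3)CC2)cc1` reaches only a limit of the assay, > 5000 nM, in this assay. Compound 2 `CC1CCN(C2CCN(S(=O)(=O)c3sc(Cl)nc3C3CC3)CC2)CC1` likewise reaches only a limit, > 5000 nM. Both measured steps are large: an at least 3100-fold lower number from compound 1 to compound 3 (3.49 log units; beyond the scatter) and an at least 3100-fold lower number from compound 2 to compound 3 (3.49 log units; beyond the scatter). Compound 4 `CC1CCN(C2CCN(S(=O)(=O)c3ccc(Cl)c(Cl)c3)CC2)CC1` carries 3,4-dichlorophenyl in place of 2-chloro-4-methyl-1,3-thiazol-5-yl on a sulfonyl sulfur. The step from compound 1 bears most directly on this change, because it also exchanged the group on the sulfonyl sulfur and gave an at least 3100-fold lower number from compound 1 to compound 3 (3.49 log units; beyond the scatter); a large rise in the number is therefore expected for compound 4, with the real chance that only a limit is reported. Compound 4 is expected to give 800 nM (30 nM to 5000 nM), a step of a 500-fold higher number from compound 3 to compound 4 (2.70 log units; beyond the scatter).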

Compound 4, half-maximal inhibitory concentration: 2.9 nM
Compound 4: middle estimate off by 280-fold (2.44 log units), on the high side; measured number outside the range, below it.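

The change of ring on the sulfonyl sulfur does not by itself cost activity in this assay: the step is a 1.8-fold higher number from compound 3 to compound 4 (0.26 log units; within the scatter), so the thiazole is not required at this position. A six-membered aromatic ring of carbon only can serve here, but the substituents on it matter, with an at least 1700-fold lower number from compound 1 to compound 4 (3.23 log units; beyond the scatter) when 3,4-dichlorophenyl replaces 4-ethylphenyl. Compound 1 stands at a limit of the assay, so the size of that step is only a bound: the limit of > 5000 nM in this assay, at which 2 of the 4 values shown sit.

On these data alone, it remains open whether a single chlorine on the phenyl ring would suffice. Also open, as far as these compounds go, is whether an amine or a nitrile in place of a chlorine would keep the number this low.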